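A few compounds are considered here, and "the series" means these few. Any claim that something is new, unique, unknown or untested is made for them only; others in the source may bear on it.

Compound 1 `O=C(Nn1c(-c2cccc([N+](=O)[O-])c2)nc2c(-c3ccc(Cl)cc3)n[nH]c2c1=O)c1ccccc1` and compound 2 `O=C(Nn1c(-c2ccccc2)nc2c(-c3ccc(Cl)cc3)n[nH]c2c1=O)c1ccccc1` share one core. In a functional assay on DU-145 cells (Homo sapiens) for inhibition, read by MTT assay, with a stated time of 2 days (a higher number here means a weaker inhibitor of growth, a lower number a stronger inhibitor of growth), compound 1 gives 17100 nM, and compound 2 gives 20100 nM; the step of a 1.2-fold higher number from compound 1 to compound 2 (0.07 log units; within the scatter) shows that removing the nitro group leaves the growth inhibition where it was. Of the two numbers shown, compound 1 sits at the lower end, with compound 2 within the scatter of it.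

Compound 3 `O=C(Nn1c(CCC2CCCC2)nc2c(-c3ccc(Cl)cc3)n[nH]c2c1=O)c1ccccc1` differs from compound 1 at the same place: 2-cyclopentylethyl in place of 3-nitrophenyl on an aromatic carbon. Within the data shown here, the only measured step bearing on this position is a 1.2-fold higher number from compound 1 to compound 2 (0.07 log units; within the scatter), and it was within the scatter; no measured step exchanges the aromatic ring for a chain with a five-membered non-aromatic ring, so the size of the coming step is uncertain. The expected change is a 1.2-fold higher number from compound 1 to compound 3 (0.07 log units; within the scatter), none beyond the scatter, with a wide range. Compound 3 is thus estimated at 20000 nM, between 7000 nM and 60000 nM.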

Compound 3, concentration for 50% growth inhibition: 10200 nM
The estimate for compound 3 lay 2.0-fold (0.29 log units) above the measured number, within the range that was stated.
By their numbers in this assay, from the lowest: compounds 3, 1 and 2 (each within the scatter of the next).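

In this assay, the aromatic ring itself can be exchanged at this place, not only the nitro group on it: a 1.7-fold lower number from compound 1 to compound 3 (0.22 log units; within the scatter), and a 2.0-fold lower number from compound 2 to compound 3 (0.29 log units; within the scatter). Both steps replace an aryl group with 2-cyclopentylethyl, which has no aromatic ring and no hydrogen-bond acceptors, yet the growth inhibition stays within the scatter, so neither an aromatic ring nor the nitro group is needed at this place to hold that level. No accompanying evidence accounts for this tolerance.

As far as these compounds go, since no group tried here moves the number beyond the scatter, it remains open whether any substituent at this place can do so. An amine or a carboxylic acid on the chain, or a longer chain, would test this, as would a change to the benzamido group.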